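Swapping the Cinnamamide Aryl Group Back to Fluorophenyl

A few compounds are considered here, and "the series" means these few. Any claim that something is new, unique, unknown or untested is made for them only; others in the source may bear on it.

Measured compounds:
compound 1, `COc1ccc(C(=O)c2cc(OC)c(OC)c(OC)c2)cc1NC(=O)/C=C/c1ccc(F)cc1`, 3400 nM in a functional assay on COLO 205 cells (Homo sapiens) for cytotoxicity, read by MTT assay, with a stated time of 72 h; on this read-out higher numbers stand for weaker inhibition and lower numbers for stronger inhibition
compound 2, `COc1ccc(/C=C/C(=O)Nc2cc(C(=O)c3cc(OC)c(OC)c(OC)c3)cc(OC)c2OC)cc1`, 4800 nM
compound 3, `C#CCOc1cccc(/C=C/C(=O)Nc2cc(C(=O)c3cc(OC)c(OC)c(OC)c3)cc(OC)c2OC)c1`, 11200 nM

Compound 3 stands as the highest of the three numbers in this assay; the nearest is compound 2, and the furthest is compound 1, both lower by margins beyond the scatter. The unmeasured compound 4 is `COc1cc(C(=O)c2cc(OC)c(OC)c(OC)c2)cc(NC(=O)/C=C/c2ccc(F)cc2)c1OC`. Relative to compound 3 the change is 4-fluorophenyl in place of 3-(propargyloxy)phenyl on a double-bonded chain carbon bound to a double-bonded chain carbon. Among the measured compounds shown here, this is the reverse kind of move to the one measured step that bears on it, a 2.3-fold higher number from compound 2 to compound 3 (0.37 log units; beyond the scatter), where the propargyloxyphenyl group entered and the number went up modestly. Compound 1, which already carries the 4-fluorophenyl group on a different core, gives 3400 nM, and on the same core as compound 4, with the 4-methoxyphenyl group, compound 2 gives 4800 nM; these two values sit close to each other. Taken together, removing the propargyloxyphenyl group is expected to bring the number back down, and the estimated step is a 2.8-fold lower number from compound 3 to compound 4 (0.45 log units; beyond the scatter). For compound 4 the estimate in this assay is therefore 4000 nM, with a range from 2000 nM to 8000 nM.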

Compound 4, half-maximal inhibitory concentration: 3100 nM
Compound 4: the middle estimate sits 1.3-fold (0.11 log units) above what was measured; the measured number falls inside the stated range.
By their numbers in this assay, from the lowest: compounds 4, 1 and 2 (each within the scatter of the next); then compound 3.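

In this assay on the shared core, the step of a 3.6-fold lower number from compound 3 to compound 4 (0.56 log units; beyond the scatter) adds a second replacement to the earlier step of a 2.3-fold higher number from compound 2 to compound 3 (0.37 log units; beyond the scatter) and shows that the 3-(propargyloxy)phenyl compound stands apart from both the 4-fluorophenyl and the 4-methoxyphenyl compounds on that core. Those two groups are not separated here, since fluoro in place of methoxy on an aromatic carbon gives a 1.5-fold lower number from compound 2 to compound 4 (0.19 log units; within the scatter) and so places the para-free comparison of these two aryl groups within the usual scatter. The core change is equally unresolved, for methoxy in place of hydrogen on an aromatic carbon gives a 1.1-fold lower number from compound 1 to compound 4 (0.04 log units; within the scatter) with the 4-fluorophenyl group held constant, so this added methoxy group shows no readable effect in this comparison.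

The compounds shown leave open how an aminophenyl or a carboxyphenyl group on the same double-bonded chain carbon would compare with these aryl groups. Nothing measured alongside these numbers accounts for the position of compound 3.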